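The source may hold more compounds than are shown below. What is called first, only, known or untested is meant among the compounds shown, and "the series" means these compounds.

Compound 2 `CC(C)NC(=O)NS(=O)(=O)c1cc(C#N)ccc1Oc1ccc(Cl)cc1` gives 9460 nM in a functional assay on HEK293 cells for antagonist activity at thromboxane A2 receptor (Homo sapiens), read by fluorescence and calcium flux (on this read-out higher numbers stand for weaker inhibition and lower numbers for stronger inhibition), and so stands at the higher of the two numbers measured in this series; compound 1 `Cc1cccc(Oc2ccc(C#N)cc2S(=O)(=O)NC(=O)NC(C)C)c1` gives 2380 nM in this assay. Within the data shown here, the single step measured so far, a 4.0-fold higher number from compound 1 to compound 2 (0.60 log units; beyond the scatter), came from swapping the methyl-bearing aromatic ring on the ether oxygen for a chlorine-bearing one.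

Compound 3 `Cc1ccccc1Nc1ccc(C#N)cc1S(=O)(=O)NC(=O)NC(C)C` has not yet been measured. It differs from compound 2 by (2-methylphenyl)amino in place of 4-chlorophenoxy on an aromatic carbon. Among the measured compounds shown here, the step of a 4.0-fold higher number from compound 1 to compound 2 (0.60 log units; beyond the scatter) bears on this only in part: it covers the exchange of a chlorine-bearing aromatic ring for a methyl-bearing one, here run in the reverse direction, but says nothing about replacing the oxygen link by an amino link, for which no measured pair exists. A lower number than that of compound 2 is therefore expected, of roughly the size seen between compound 2 and compound 1, but with a wide margin.

Compound 3 is estimated at 2500 nM, within 600 nM to 10000 nM. The expected step is a 3.8-fold lower number from compound 2 to compound 3 (0.58 log units; beyond the scatter).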

Compound 3, half-maximal inhibitory concentration: 7240 nM
Estimate against measurement, compound 3: 2.9-fold (0.46 log units) below; low and high end bracket the measured number.
By their numbers in this assay, from the lowest: compound 1; then compounds 3 and 2 (each within the scatter of the next).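

In this assay the exchange of 4-chlorophenoxy for (2-methylphenyl)amino at this aromatic carbon, para to a cyano group, gives a 1.3-fold lower number from compound 2 to compound 3 (0.12 log units; within the scatter) and so leaves these two groups unresolved on this read-out, despite the different link and ring substituent and the hydrogen-bond donor that enters. The exchange of 3-methylphenoxy for (2-methylphenyl)amino gives a 3.0-fold higher number from compound 1 to compound 3 (0.48 log units; beyond the scatter) and shows that a methyl-bearing ring at this carbon does not by itself bring a compound to the number of compound 1, which now stands apart from both others. The data offer no measured reason for either step.

From the compounds shown here alone, this last exchange alters the link and the place of the methyl together, so the share of each stays unknown, and a (3-methylphenyl)amino group at this carbon would separate them. Also open, going by these compounds, is how a methylene link in place of the oxygen or the amino nitrogen, or a ring carrying a carboxylic acid, would read in this assay on the same core.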